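This account rests on a few compounds, and the source may have more. Where it says the series, first, only, none or still open, it means among the compounds named here.

Measured so far in an ADME assay on Vero cells (Chlorocebus sabaeus) for cytotoxicity, read by MTT assay, with a stated time of 24 h; on this read-out higher numbers stand for weaker inhibition and lower numbers for stronger inhibition:
- compound 1, `O=C(CC1SC(=O)NC1=O)Oc1ccc(/C=N/NC(=O)c2ccncc2)cc1Br`: 190 ug/mL
- compound 2, `COc1cc(/C=N/NC(=O)c2ccncc2)ccc1OC(=O)CC1SC(=O)NC1=O`: 203 ug/mL

Going by the values given here, compound 2 gives the highest of the two numbers in this assay, but the gap to compound 1 is small: the one measured step, a 1.1-fold higher number from compound 1 to compound 2 (0.03 log units; within the scatter), sits inside the scatter, so the two values cannot be ordered.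

Compound 3, `CCOc1cc(/C=N/NC(=O)c2ccncc2)ccc1OC(=O)CC1SC(=O)NC1=O`, is the next member. It differs from compound 2 by methyl in place of hydrogen on a saturated chain carbon bound to an oxygen on an aromatic ring, which the shared core of compound 2 carries unchanged otherwise.

Among the compounds with values here, no measured step touches this saturated chain carbon. Within the data shown here, the only step in hand, a 1.1-fold higher number from compound 1 to compound 2 (0.03 log units; within the scatter), swaps the substituent on the aromatic carbon and produced no movement beyond the scatter. That step does not bear directly on the change to compound 3, and nothing in the two numbers points either way. With both measured values lying close together and the change being a single methyl on the chain, the expectation for this assay is a step of a 1.0-fold higher number from compound 2 to compound 3 (0.00 log units; within the scatter), none beyond the scatter.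

Compound 3 is therefore estimated at 205 ug/mL, with a range from 130 ug/mL to 320 ug/mL.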

Compound 3, half-maximal inhibitory concentration: 50.9 ug/mL
Compound 3: middle estimate off by 4.0-fold (0.61 log units), on the high side; measured number below the stated range.
By their numbers in this assay, from the lowest: compound 3; then compounds 1 and 2 (each within the scatter of the next).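

In this assay, going by these compounds alone, the first change on the saturated chain carbon bound to an oxygen on an aromatic ring moves the number beyond the scatter: methyl in place of hydrogen, read as methoxy to ethoxy, gives (a 4.0-fold lower number from compound 2 to compound 3 (0.60 log units; beyond the scatter)), toward stronger inhibition on this read-out. Ethoxy in place of bromo on the aromatic carbon gives (a 3.7-fold lower number from compound 1 to compound 3 (0.57 log units; beyond the scatter)), so compound 3 stands apart from compounds 1 and 2, and the substituent at this place is no longer shown to be without consequence, as the earlier swap of bromo for methoxy alone suggested. Nothing in hand accounts for the size of this single-methyl step.

Methoxy and ethoxy give only two points on this chain, so whether a longer chain such as propoxy or butoxy continues the direction of the step, holds it or reverses it remains open. Also open, going by these compounds, is how the number responds when the chain ends in an amine or a carboxylic acid, or when a hydroxy group stands on the aromatic carbon in place of the ether.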